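Thiourea-linked sulfonamides: aryl change from compound 3 to compound 4

This account rests on a few compounds, and the source may have more. Where it says the series, first, only, none or still open, it means among the compounds named here.

For the measured compounds named here, compound 3 `NS(=O)(=O)c1ccc(NC(=S)Nc2ccc3ncnc(Nc4ccc(F)c(Br)c4)c3c2)cc1` gives 9980 nM in a functional assay on NCI-H1975 cells (Homo sapiens) for antiproliferative activity, read by MTT assay, with a stated time of 72 h (on this read-out lower numbers stand for stronger inhibition and higher numbers for weaker inhibition), the lowest of the three numbers so far. Compound 2 `COc1cc2ncnc(Nc3ccc(C)cc3)c2cc1OCCCCC(=O)Nc1ccc(S(N)(=O)=O)cc1` gives 19300 nM, within the scatter of compound 3; compound 1 `COc1cc2ncnc(Nc3cccc(C)c3)c2cc1OCCCCC(=O)Nc1ccc(S(N)(=O)=O)cc1` gives 32100 nM, beyond the scatter from compound 3. Compound 4 `NS(=O)(=O)c1ccc(NC(=S)Nc2ccc3ncnc(Nc4cccc(Cl)c4)c3c2)cc1` differs from compound 3 by 3-chlorophenyl in place of 3-bromo-4-fluorophenyl on a nitrogen on an aromatic ring. Going by the values given here, the only measured step, a 1.7-fold lower number from compound 1 to compound 2 (0.22 log units; within the scatter), concerns a methylphenyl change on a different linker and does not bear on this halogenated aryl exchange; no halogen swap has been measured. No step beyond the scatter is therefore expected in this assay, so compound 4 is estimated at 10000 nM, range 3000 nM to 35000 nM. That expectation corresponds to a 1.0-fold higher number from compound 3 to compound 4 (0.00 log units; within the scatter).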

Compound 4, half-maximal inhibitory concentration: 39800 nM
Compound 4: the middle estimate sits 4.0-fold (0.60 log units) below what was measured; the measured number lies above the stated range.
By their numbers in this assay, from the lowest: compounds 3, 2, 1 and 4 (each within the scatter of the next, the first and the last beyond it).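

In this assay, for the compounds shown here, the step of a 4.0-fold higher number from compound 3 to compound 4 (0.60 log units; beyond the scatter) is the first one that lies beyond the scatter, and it comes from the aryl group on a nitrogen on an aromatic ring. The earlier methylphenyl exchange at this kind of place, on a different linker, stayed within the scatter, so the 3-bromo-4-fluorophenyl and 3-chlorophenyl pair shows that the number can respond to this aryl group. Nothing measured here accounts for the step.

Open, as far as these compounds go, is whether the step follows the bromine, the fluorine or the chlorine. 3-Bromophenyl and 3-chloro-4-fluorophenyl on the same thiourea-linked compound would separate these.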